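This account rests on a few compounds, and the source may have more. Where it says the series, first, only, none or still open, it means among the compounds named here.

Among the measured compounds shown here, compound 1 `CC#C[C@H]1CN(S(=O)(=O)c2ccc(N)nc2)CCN1c1ccc(S(=O)(=NC)C(F)(F)F)cc1` stands highest of the two numbers so far in an assay on isolated protein for inhibition of glucokinase regulatory protein (Homo sapiens), read by AlphaScreen, with stated times of 20 min and 4 h (a higher number here means a weaker inhibitor, a lower number a stronger inhibitor), where compound 1 gives 266 nM. Compound 2 `CC#C[C@H]1CN(S(=O)(=O)c2ccc(N)nc2)CCN1c1ccc(C(C)(O)C(F)(F)F)nc1`, which also carries a hydroxyl-bearing trifluoromethyl carbon on its aromatic ring, gives 69 nM in this assay, a lower number beyond the scatter. Compound 3 `CC#C[C@H]1CN(S(=O)(=O)c2ccc(N)nc2)CCN1c1ccc(C(O)(COC)C(F)(F)F)cc1` differs from compound 1 in one place: a group of 9 heavy atoms (4 carbon, 2 oxygen, 3 fluorine; no ring) in place of a group of 8 heavy atoms (2 carbon, 1 nitrogen, 1 oxygen, 3 fluorine, 1 sulfur; no ring), on an aromatic carbon. For the measured compounds named here, no step between measured compounds covers this exact change, so the expectation rests on compound 2 and its 69 nM. A step of moderate size toward a lower number is expected, a 2.4-fold lower number from compound 1 to compound 3 (0.38 log units; beyond the scatter). Compound 3 is estimated at 110 nM in this assay, with a range from 40 nM to 300 nM.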

Compound 3, half-maximal inhibitory concentration: 16 nM
Estimate against measurement, compound 3: 6.9-fold (0.84 log units) above; the measured number lies below the stated range.
By their numbers in this assay, from the lowest: compound 3; then compound 2; then compound 1.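

The exchange of the sulfur-bearing group of 8 heavy atoms for the group of 9 heavy atoms gives a 17-fold lower number from compound 1 to compound 3 (1.22 log units; beyond the scatter) in this assay and shows that this position, on an aromatic carbon para to a large group, strongly affects the number. The entering group carries 1 hydrogen-bond donor and the leaving group 0, but this single step cannot separate that difference from the others. Nothing measured here accounts for the size of the step.

Which part of the entering group carries the step remains open. Also open, going by these compounds, is how a longer ether chain or an amine on the same carbon would read.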